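This account rests on a few compounds, and the source may have more. Where it says the series, first, only, none or still open, it means among the compounds named here.

Working notes on the series.

Of the compounds shown here, three have been measured in a functional assay on A549 cells (Homo sapiens) for antiproliferative activity, read by MTT assay, with a stated time of 48 h; a higher number here means a weaker inhibitor, a lower number a stronger inhibitor. Compound 1 `N#CC1=C(N)Oc2c(c3nc4ccccc4nc3c3ccccc23)C12C(=O)N(Cc1cnnn1-c1ccc(F)c(Cl)c1)c1ccccc12` gives in this assay a limit rather than a number, > 50000 nM. Compound 2 `N#CC1=C(N)Oc2c(c3nc4ccccc4nc3c3ccccc23)C12C(=O)N(Cc1cnnn1-c1ccc(Cl)c(Cl)c1)c1ccccc12` arises from compound 1 by chloro in place of fluoro on an aromatic carbon. In this assay compound 2 also gives only a limit, > 50000 nM. The measured step that the two limits leave unreadable from compound 1 to compound 2 is therefore of unreadable size, because both of its ends sit at the limit of > 50000 nM in this assay, at which 3 of the 3 values shown sit.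

Compound 3 `N#CC1=C(N)Oc2c(N)cc3nc4ccccc4nc3c2C12C(=O)N(Cc1cnnn1-c1ccc(F)cc1)c1ccccc12` carries a different core; the difference between the cores of compound 1 and compound 3 is not broken down here. In this assay compound 3 likewise gives a limit, > 50000 nM.

Compound 4 `N#CC1=C(N)Oc2c(N)cc3nc4ccccc4nc3c2C12C(=O)N(Cc1cnnn1-c1ccc(Cl)cc1)c1ccccc12` has not yet been measured. It differs from compound 3 by chloro in place of fluoro on an aromatic carbon. Going by the values given here, this is the same kind of change as the one from compound 1 to compound 2, not the same change: around the place in compound 1 the aromatic carbon is also ortho to a chloro group, and in compound 3 it is not.

Among the compounds with values here, no measured step in this assay is readable, and all three values shown sit at the limit of > 50000 nM in this assay, at which 3 of the 3 values shown sit; nothing among the measured compounds points to a readable gain from this kind of change. The expected step, resting on the unreadable step that the two limits leave unreadable from compound 1 to compound 2 and on compound 3 sitting at the limit of > 50000 nM in this assay, at which 3 of the 3 values shown sit, is a step that the limit leaves unreadable from compound 3 to compound 4. Compound 4 is estimated in this assay at 80000 nM, with an expected range from 30000 nM to 300000 nM, and most likely again only a limit.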

Compound 4, half-maximal inhibitory concentration: > 50000 nM
Compound 4: no number, only a limit; the forecaster's own chance of this, stated with the estimate: 85%; the middle value is on the limit's open side.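

In this assay compound 4 gives > 50000 nM, a limit and not a number. The step from compound 3 to compound 4 therefore cannot be read, as both of its ends are limits: the limit of > 50000 nM in this assay, at which 4 of the 4 values shown sit.

The compounds shown leave open whether chloro in place of fluoro has any effect in this assay, and what structure in this series, if any, would give a readable number there.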